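Taking the substituent off compound 2

The source may hold more compounds than are shown below. What is called first, only, known or untested is meant among the compounds shown, and "the series" means these compounds.

Compound 2 `CCOc1ccc(Br)cc1-c1cc(Nc2ccc(/C(C)=N\O)cc2)nc(N)n1` is the stronger of the two inhibitors measured so far in a functional assay on K562 cells (Homo sapiens) for inhibition; a higher number here means a weaker inhibitor, a lower number a stronger inhibitor. Compound 2 reads < 50 nM, which is a limit and not a number. Compound 1 `CCOc1ccc(Br)cc1-c1cc(Nc2ccc(B(O)O)cc2)nc(N)n1` gives 200 nM in this assay. The two differ only in the group on one aromatic carbon, and the measured change is an at least 4.0-fold lower number from compound 1 to compound 2 (0.60 log units; beyond the scatter). Its size rests on (the limit of < 50 nM in this assay, at which 1 of the 2 values shown sits).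

Compound 3 `CCOc1ccc(Br)cc1-c1cc(Nc2ccccc2)nc(N)n1` has a hydrogen atom in place of a group of 4 heavy atoms (2 carbon, 1 nitrogen, 1 oxygen; no ring), on an aromatic carbon. Among the compounds with values here, no measured compound has only hydrogen at this carbon, so the evidence is indirect. Exchanging one group for another there gave an at least 4.0-fold lower number from compound 1 to compound 2 (0.60 log units; beyond the scatter), so the number clearly responds to what sits at this carbon, and a weaker inhibitor is expected without compound 2's group. The expected change is an at least 6.0-fold higher number from compound 2 to compound 3 (0.77 log units; beyond the scatter), a wide estimate. For compound 3 the estimated value is 300 nM, within an expected range of 60 nM to 1500 nM.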

Compound 3, half-maximal inhibitory concentration: 260 nM
For compound 3 the middle estimate is 1.2-fold (0.06 log units) above the measured one; low and high end bracket the measured number.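

Hydrogen at this carbon now gives a baseline: taking the group off gives an at least 5.2-fold higher number from compound 2 to compound 3 (0.71 log units; beyond the scatter) in this assay and so shows that the group with no common name brings a real gain. The boron-bearing group brings no such gain that can be read, with a 1.3-fold higher number from compound 1 to compound 3 (0.11 log units; within the scatter) as the whole difference between it and hydrogen. The earlier step therefore reflects a gain from the group of compound 2 and not a loss from the boron-bearing group, although the full size of that gain stays unknown: the limit of < 50 nM in this assay, at which 1 of the 3 values shown sits.

What the compounds shown leave open is whether this gain needs the whole group or could come from a simpler one at the same carbon, such as an amine or a carboxylic acid. They also leave open whether a longer chain there would keep the gain.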